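Swapping a tert-butyl ester for an ethyl ester

This account rests on a few compounds, and the source may have more. Where it says the series, first, only, none or still open, it means among the compounds named here.

Measured compounds:
compound 1 `CCOC(=O)/C=C/NC(=O)[C@H](O)C(C)(C)CO`: 36%
compound 2 `CC(C)(C)OC(=O)/C=C/NC(=O)[C@H](O)C(C)(C)CO`: 0%
compound 3 `CC(C)(C)OC(=O)/C=C\NC(=O)[C@@H](O)C(C)(C)CO`: 26%

All three were tested in an ADME assay on WI-38 cells (Homo sapiens) for inhibition, read by CellTiter-Glo, with a stated time of 48 h, tested at 100 uM; a higher number here means more inhibition at the concentration tested (going by the name of the read-out), a lower number less inhibition. Compound 4 `CCOC(=O)/C=C\NC(=O)[C@@H](O)C(C)(C)CO` has not yet been measured there. It differs from compound 3 by ethyl in place of tert-butyl on an oxygen next to a carbonyl group. The same change already appears once among the measured compounds, from compound 2 to compound 1, as ethyl in place of tert-butyl on an oxygen next to a carbonyl group, where it gave a number 36 percentage points higher from compound 2 to compound 1 (beyond the scatter). The place of the change is the same word for word in both pairs, so this is the same change applied to a different core. The cores of compound 2 and compound 3 differ by the two compounds have the same atoms and bonds and differ only in configuration as drawn: 2 of 2 stereo elements differ; a stereocentre at a saturated chain carbon is drawn R in compound 2 and S in compound 3; a double bond is drawn E in compound 2 and Z in compound 3; between them the measured step is a number 26 percentage points higher from compound 2 to compound 3 (beyond the scatter), and this step rests on (the fact that compounds 2 and 3 differ only in the configuration as drawn). Compound 3 and compound 1 lie within the usual scatter of each other.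

For compound 4 the expected step is a number 26 percentage points higher from compound 3 to compound 4 (beyond the scatter), set beside the measured a number 36 percentage points higher from compound 2 to compound 1 (beyond the scatter). Compound 4 is therefore estimated at 52%, expected to fall between 30% and 75%.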

Compound 4, a percentage reported as inhibition, at one concentration (the size of the read-out at that concentration, not a potency): -6%
Beside the measured number, compound 4's estimate is 58 percentage points above it; measured number outside the range, below it.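

In this assay, putting ethyl in place of tert-butyl gave a number 32 percentage points lower from compound 3 to compound 4 (beyond the scatter), so the change did not carry over from one core to the other and instead reversed direction: the same change on two cores in this assay, a number 36 percentage points higher (beyond the scatter) from compound 2 to compound 1 and a number 32 percentage points lower (beyond the scatter) from compound 3 to compound 4, 68 percentage points apart, beyond the scatter of two such steps. The two ethyl esters also lie far apart, with a number 42 percentage points lower from compound 1 to compound 4 (beyond the scatter), so the result of this swap in this small series depends on the core, even when the cores differ only in how they are drawn in space: the fact that compounds 1 and 4 differ only in the configuration as drawn. The stereocentre and the double bond differ together in both comparisons, so these data do not show which of the two matters, why the direction reverses, or whether the pattern would hold in any other core.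

Still open, from the compounds shown here alone, is how a compound would read with only the stereocentre or only the double bond changed. Also open, going by these compounds, is what other groups on the oxygen, such as a longer chain or a benzyl group, would give in this assay.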